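Triazole-linked series: a 2-fluorobenzyl swap on compound 2

A few compounds are considered here, and "the series" means these few. Any claim that something is new, unique, unknown or untested is made for them only; others in the source may bear on it.

Measured so far:
compound 1 `O=C1/C(=C/c2ccccc2F)CN(Cc2cn(Cc3ccccc3Cl)nn2)C/C1=C\c1ccccc1F` — 7500 nM
compound 2 `COc1ccc(/C=C2\CN(Cc3cn(Cc4cccc(Cl)c4)nn3)C/C(=C\c3ccc(OC)cc3)C2=O)cc1` — 15400 nM

Notes. In a functional assay on DU-145 cells (Homo sapiens) for cytotoxicity, read by MTT assay, with a stated time of 24 h (on this read-out higher numbers stand for weaker inhibition and lower numbers for stronger inhibition), compound 2 gives 15400 nM, the highest of the two numbers; compound 1 gives 7500 nM, a lower number, and the gap between them lies beyond the usual scatter. Compound 1 and compound 2 differ from each other in more than one place, so no single-change step can be read from them.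

Compound 3 `COc1ccc(/C=C2\CN(Cc3cn(Cc4ccccc4F)nn3)C/C(=C\c3ccc(OC)cc3)C2=O)cc1` is the next member and is not yet measured. Relative to compound 2 it carries 2-fluorophenyl in place of 3-chlorophenyl on a saturated chain carbon bound to an aromatic nitrogen. The group that enters is the same one that compound 1 bears at that position, but compound 1 differs from compound 2 elsewhere as well. The value of compound 1, 7500 nM, is therefore only a loose pointer.

The expected step of a 1.5-fold lower number from compound 2 to compound 3 (0.19 log units; within the scatter) is a modest move toward a lower number, not confidently beyond the scatter. Compound 3 is therefore estimated at 10000 nM in this assay, with a likely range from 4000 nM to 25000 nM.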

Compound 3, half-maximal inhibitory concentration: 32600 nM
Estimate against measurement, compound 3: 3.3-fold (0.51 log units) below; measured number above the stated range.
By their numbers in this assay, from the lowest: compound 1; then compound 2; then compound 3.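

In this assay, among these compounds, replacing 3-chlorobenzyl with 2-fluorobenzyl gives a 2.1-fold higher number from compound 2 to compound 3 (0.33 log units; beyond the scatter), the first single-change step. With the rest of the structure unchanged, the aryl group on a saturated chain carbon bound to an aromatic nitrogen therefore affects the read-out on its own, and this exchange moves it toward weaker inhibition. No supporting measurement bears on the reason for this shift.

This one step changes the halogen and its ring position together, so their separate contributions cannot be read from it. Also open, from the compounds shown here alone, is how this read-out would respond at the same place to an unsubstituted benzyl, a 3-fluorobenzyl, or a longer chain ending in an amine or a carboxylic acid.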